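A few compounds are considered here, and "the series" means these few. Any claim that something is new, unique, unknown or untested is made for them only; others in the source may bear on it.

Among the compounds with values here, compound 2 `Cc1c(OCCCCOc2ccc(C(=O)O)cc2)ccc(C(=O)CC(C)C)c1O` gives 122 nM in an assay on HEK293 cells for positive allosteric modulation of metabotropic glutamate receptor 2 (Rattus norvegicus), read by thallium flux, with a stated time of 2.5 min (on this read-out lower numbers stand for an effect already at smaller amounts and higher numbers for an effect only at larger amounts of compound), and stands lowest of the two numbers so far; compound 1 `Cc1c(OCCCCOc2ccc(C(=O)O)cc2)ccc(C(=O)CC2CCCC2)c1O` gives 824 nM in this assay, and the step of a 6.8-fold lower number from compound 1 to compound 2 (0.83 log units; beyond the scatter) is the only measured one. Compound 3 `Cc1c(OCCCCOc2ccccc2C(=O)O)ccc(C(=O)CC(C)C)c1O` differs from compound 2 by 2-carboxyphenyl in place of 4-carboxyphenyl on an oxygen on a saturated carbon. Within the data shown here, no measured step touches that place, so the step from compound 1 to compound 2 bears on it only as a sign of the series' range, not of direction. The step of a 3.3-fold higher number from compound 2 to compound 3 (0.52 log units; beyond the scatter) is therefore an estimate with wide bounds: compound 3 is expected at 400 nM, between 120 nM and 1500 nM.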

Compound 3, half-maximal effective concentration: 415 nM
Beside the measured number, compound 3's estimate is 1.0-fold (0.02 log units) below it, within the range that was stated.
By their numbers in this assay, from the lowest: compound 2; then compounds 3 and 1 (each within the scatter of the next).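

In this assay, exchanging 4-carboxyphenyl for 2-carboxyphenyl on an oxygen on a saturated carbon gives a 3.4-fold higher number from compound 2 to compound 3 (0.53 log units; beyond the scatter) with the atoms unchanged and only their joining different. Within the data shown here, this is the first reading at this place, as the earlier step concerned only the saturated chain carbon bound to a carbonyl carbon, and with isopropyl held constant 4-carboxyphenyl gives the lower number. No available evidence accounts for this difference.

From the compounds shown here alone, whether 3-carboxyphenyl would fit this comparison remains open, as does the effect of a tetrazole replacing the carboxylic acid. Going by these compounds, it is also open whether the same exchange gives a similar step with cyclopentyl in place of isopropyl.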